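The compounds below may be only part of what the source reports. "The series", "measured", "known", "first", "only" and "open" are said of these compounds alone.

Of the compounds shown here, three have so far been measured in a functional assay on NIH3T3 cells (Mus musculus); on this read-out lower numbers stand for an effect already at smaller amounts and higher numbers for an effect only at larger amounts of compound. Within the data shown here, compound 1 `N#Cc1ccc(Cn2cncc2CNc2ccc(C(=O)NCc3ccccc3)c(-c3ccccc3)c2)cc1` is the first of them. In this assay compound 1 gives only a limit, > 10 uM. Compound 2 `COC(=O)[C@H](CCSC)NC(=O)c1ccc(NCc2cncn2Cc2ccc(Cl)cc2)cc1-c1ccccc1` is the starting point of the step followed here. In this assay compound 2 likewise gives only a limit, > 10 uM. Compound 3 `CSCC[C@H](NC(=O)c1ccc(NCc2cncn2Cc2ccc(Cl)cc2)cc1-c1ccccc1)C(=O)O` carries hydrogen in place of methyl on an oxygen next to a carbonyl group. In this assay compound 3 also gives only a limit, > 10 uM. Among the measured compounds shown here, the one step between measured compounds that differ in a single place, a step that the two limits leave unreadable from compound 2 to compound 3, is thus unreadable in size, and the whole picture is summed up by the limit of > 10 uM in this assay, at which 3 of the 3 values shown sit: every value shown rests at the same limit.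

Compound 4 `COC(=O)[C@H](CCSC)NC(=O)c1ccc(NCc2cncn2Cc2ccccc2C#N)cc1-c1ccccc1` has not yet been measured. It differs from compound 2 by 2-cyanophenyl in place of 4-chlorophenyl on a saturated chain carbon bound to an aromatic nitrogen. For the measured compounds named here, no measured step bears on this change, since the only measured step runs between two limits and offers no size. Nothing in the numbers shown gives reason to expect a change beyond the scatter, so the step from compound 2 to compound 4 is estimated at a step that the limit leaves unreadable from compound 2 to compound 4. Compound 4 is therefore expected to give about 15 uM in this assay, within a range from 4 uM to 60 uM, most probably again as a limit.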

Compound 4, concentration for half-maximal effect: > 10 uM
Compound 4 gave a limit, no number (the forecaster's own chance of this, stated with the estimate: 70%); the middle value does not contradict the limit.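

In this assay compound 4 gives only a limit, > 10 uM. Compound 2 gives a limit as well, so no size can be read for the change from compound 2 to compound 4. The compounds shown leave open at what concentration any of them acts, and whether either change alters it, as the picture remains: the limit of > 10 uM in this assay, at which 4 of the 4 values shown sit.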